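This account rests on a few compounds, and the source may have more. Where it says the series, first, only, none or still open, it means among the compounds named here.

Working notes on the series. The common scaffold is carried by compound 1 `C[C@@H]1CN(c2nnc(Cc3ccccc3)c3ccccc23)CCN1c1ccc(C(F)(F)F)cn1`, compound 2 `CC[C@@H]1CN(c2nnc(Cc3ccccc3)c3ccccc23)CCN1c1ccc(C#N)cn1` and compound 3 `C[C@@H]1CN(c2nnc(-c3ccccc3)c3ccccc23)CCN1c1ccc(C#N)cn1`; compound 4 `C[C@@H]1CN(c2nnc(CCc3ccccc3)c3ccccc23)CCN1c1ccc(C#N)cn1` is the next member and has not yet been measured. In an assay on Sf9 cells for inhibition of sphingosine-1-phosphate lyase 1 (Homo sapiens), with a stated time of 1 h (on this read-out higher numbers stand for weaker inhibition and lower numbers for stronger inhibition), compound 1 gives 30000 nM. In this assay compound 2 gives 1700 nM. For compound 3 this assay reports only a limit, > 30000 nM, so the value of compound 3 is a limit and not a number; it stands at the limit of > 30000 nM in this assay, at which 1 of the 3 values shown sits. No two of the measured compounds differ in one place only, so no single step can be read from these three values, and the gap between compound 1 and compound 2, which differ in two places, is all that the numbers show.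

The change from compound 3 to compound 4 is phenethyl in place of phenyl on an aromatic carbon. With compound 3 sitting at a limit, the step can only be stated as an expectation: the step from compound 3 to compound 4 is expected to be a gain in this assay, an at least 5.0-fold lower number from compound 3 to compound 4 (0.69 log units; beyond the scatter), larger than the scatter, although a limit may again be reported. Compound 4 is estimated at 6000 nM in this assay, with a range from 1200 nM to 30000 nM.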

Compound 4, half-maximal inhibitory concentration: 30000 nM
Beside the measured number, compound 4's estimate is 5.0-fold (0.70 log units) below it; the measured number falls inside the stated range.
By their numbers in this assay, from the lowest: compound 2; then compounds 1 and 4 (each within the scatter of the next).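

With phenethyl in place of phenyl on this aromatic carbon, next to the ring nitrogen, the series now has its first single-place change, and it reads as a number no higher from compound 3 to compound 4 (the limit leaves the size open). In this assay compound 4 gives 30000 nM, a number and not a limit, so this position now carries a phenyl-bearing chain with a readable value. Compound 3 stands at a limit, > 30000 nM, and the size of this step stays unread because of that limit: the limit of > 30000 nM in this assay, at which 1 of the 4 values shown sits.

The compounds shown leave open how a longer chain such as phenylpropyl, or an amine or a carboxylic acid carried on the chain, would read at this aromatic carbon. They also leave open how the group on this carbon in compound 2 compares with phenethyl when all else is equal, and how nitrile and trifluoromethyl compare on an otherwise identical compound, since no pair shown isolates either change.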